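What an Isopropyl Group Might Do to Compound 2

A few compounds are considered here, and "the series" means these few. Any claim that something is new, unique, unknown or untested is made for them only; others in the source may bear on it.

Within the data shown here, in an ADME assay on L1210 cells (Mus musculus) for cytotoxicity, with a stated time of 48 h (a higher number here means a weaker inhibitor, a lower number a stronger inhibitor), compound 2 (`C=C1[C@H](C)CCC[C@]1(C)CC/C(C)=C/CC1=C(O)C(=O)C=C(NCC(=O)O)C1=O`) gives 4 ug/mL, the only true number so far. Compound 1 (`C=C1[C@H](C)CCC[C@]1(C)CC/C(C)=C/CC1=C(O)C(=O)C=C(N[C@H](C(=O)O)[C@@H](C)O)C1=O`) gives > 10 ug/mL, which is a limit of the assay and not a number. Compound 3 (`C=C1[C@H](C)CCC[C@]1(C)CC/C(C)=C/CC1=C(O)C(=O)C=C(N[C@H](C(=O)O)C(C)C)C1=O`) has not yet been measured. It differs from compound 2 by one change: isopropyl in place of hydrogen on a saturated chain carbon bound to an amine nitrogen and a carbonyl carbon. Isopropyl replaces hydrogen on a saturated chain carbon bound to an amine nitrogen and a carbonyl carbon.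

Among the measured compounds shown here, one measured step bears on this change. It is an at least 2.5-fold lower number from compound 1 to compound 2 (0.39 log units; beyond the scatter), where hydrogen replaced 1-hydroxyethyl at that same place and the number fell beyond the usual scatter. Compound 3 again carries a group there instead of hydrogen, so a move towards a higher number in this assay seems more likely than a fall. Isopropyl is a different group from 1-hydroxyethyl, however, and a single step is thin support. The expected change is a 1.5-fold higher number from compound 2 to compound 3 (0.18 log units; within the scatter), and it is modest. For compound 3 the estimated value is 6 ug/mL, with an expected range of 2.5 ug/mL to 15 ug/mL.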

Compound 3, half-maximal inhibitory concentration: 4.4 ug/mL
Beside the measured number, compound 3's estimate is 1.4-fold (0.13 log units) above it; the measured number falls inside the stated range.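

In this assay, putting isopropyl in place of hydrogen on this saturated chain carbon gives a 1.1-fold higher number from compound 2 to compound 3 (0.04 log units; within the scatter), so compound 2 and compound 3 cannot be told apart here, and a group of this size at this place need not move the number at all. The earlier step suggested that any group here might raise the number, but replacing 1-hydroxyethyl with isopropyl gives an at least 2.2-fold lower number from compound 1 to compound 3 (0.35 log units; beyond the scatter), which shows that the identity of the group matters and not merely the presence of one. The reading for compound 1, > 10 ug/mL, is a limit of the assay and not a number, so both steps from it give only a minimum size: the limit of > 10 ug/mL in this assay, at which 1 of the 3 values shown sits.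

As far as these compounds go, whether a longer chain, a benzyl group or a chain ending in an amine at this carbon would also match compound 2 and compound 3 remains open. It is also unclear whether the hydroxyl of 1-hydroxyethyl alone sets compound 1 apart, and a comparison with a methoxyethyl group at the same place would bear on that question.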